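This account rests on a few compounds, and the source may have more. Where it says the series, first, only, none or still open, it means among the compounds named here.

In a functional assay on MCF7 cells (Homo sapiens) for antiproliferative activity, read by MTT assay, with a stated time of 48 h (a lower number here means a stronger inhibitor, a higher number a weaker inhibitor), compound 1 `O=C1NC2(C3=C(C(=O)C4C=CC=CC4C3=O)c3ccccc32)c2ccccc21` gives 820 nM, and compound 2 `O=C1NC2(C3=C(C(=O)C4C=CC=CC4C3=O)c3ccccc32)c2cc(Cl)c(Cl)cc21` gives 1020 nM. Among the measured compounds shown here, these are the only two numbers available, and they lie within the scatter of each other, so compound 1 stands level with compound 2 and neither can be ranked ahead.

The next compound to be tested is compound 3 `O=C1NC2(C3=C(C(=O)C4C=CC=CC4C3=O)c3cc(Cl)ccc32)c2ccccc21`, which keeps the core of compound 1 and makes one change: chloro in place of hydrogen on an aromatic carbon. For the measured compounds named here, no measured pair here differs in a single place, so the data give no direct reading of what this change does. Going by the values given here, the nearest guide is compound 2, whose 1020 nM shows that the only other compound measured stays close to compound 1. In this assay, therefore, no step beyond the scatter is expected, and no direction is favoured. The expected size of the change is a 1.0-fold higher number from compound 1 to compound 3 (0.02 log units; within the scatter), which would remain within the scatter. For compound 3 the estimated value is 850 nM, with an expected range of 380 nM to 1900 nM.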

Compound 3, half-maximal inhibitory concentration: 5110 nM
Beside the measured number, compound 3's estimate is 6.0-fold (0.78 log units) below it; the measured number lies above the stated range.
By their numbers in this assay, from the lowest: compounds 1 and 2 (each within the scatter of the next); then compound 3.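

In this assay, among the compounds shown here, chloro in place of hydrogen on an aromatic carbon gives a 6.2-fold higher number from compound 1 to compound 3 (0.79 log units; beyond the scatter) and so provides the first readable step between two compounds that differ in one place. The step shows that this position, on a six-membered aromatic ring of carbon only, meta to a fused ring and para to a fused ring, is sensitive to substitution, since a single chlorine atom is enough to move the number beyond the scatter towards weaker inhibition. No measurement available here explains this loss of activity.

The compounds shown leave open whether the loss is specific to chloro or would also follow from another group at this position, such as fluoro, methyl, methoxy or an amine. They also leave open whether chloro would give a step of similar size at the other open carbons of the same ring, so this single step describes one group at one position and sets no wider pattern for the series.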